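This account rests on a few compounds, and the source may have more. Where it says the series, first, only, none or still open, it means among the compounds named here.

Among the measured compounds shown here, compound 1, with the structure `CC(=O)O[C@@H]1OC(=O)[C@](C)(C(C)=O)[C@@H]1C`, is the only compound here with a plain number: in a functional assay on HT-29 cells (Homo sapiens) for cytotoxicity, read by MTT assay (on this read-out lower numbers stand for stronger inhibition and higher numbers for weaker inhibition), compound 1 gives 5000 nM. Compound 2, `CC(=O)O[C@@H]1OC(=O)[C@](OC(C)=O)(C(C)=O)[C@@H]1C`, differs from it by acetoxy in place of methyl on a saturated ring carbon. In this assay compound 2 reaches only > 50000 nM, which is a limit of the assay rather than a number. That change gave an at least 10-fold higher number from compound 1 to compound 2 (1.00 log units; beyond the scatter), and it rests on (the limit of > 50000 nM in this assay, at which 1 of the 2 values shown sits). Compound 3, `CC(=O)O[C@@H]1OC(=O)[C@](C)(C(=O)CBr)[C@@H]1C`, is not yet measured; it differs from compound 1 by bromo in place of hydrogen on a saturated chain carbon bound to a carbonyl carbon. For the measured compounds named here, the one measured step concerns a different place on the core of compound 1 and offers no guide to this change, so no step beyond the scatter is expected, and the estimate for compound 3 is a step of a 1.7-fold lower number from compound 1 to compound 3 (0.22 log units; within the scatter). Compound 3 is therefore expected to give about 3000 nM in this assay, between 500 nM and 15000 nM.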

Compound 3, half-maximal inhibitory concentration: 6000 nM
The estimate for compound 3 lay 2.0-fold (0.30 log units) below the measured number, and the stated range covers the measured number.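

The earlier step showed only a change on a saturated ring carbon of compound 1, so the acetyl side chain remained untested until now. In this assay, changing acetyl to (bromomethyl)carbonyl gives a 1.2-fold higher number from compound 1 to compound 3 (0.08 log units; within the scatter) and thus leaves the two compounds indistinguishable on this read-out, so this position accepts one bromo in place of hydrogen without a step beyond the scatter. Nothing in the data shown offers an explanation for this outcome. Going by these compounds, whether other groups on this chain carbon, such as an amine, a carboxylic acid or a longer chain, would also match compound 1 remains open. So does whether the bromo would give the same result when combined with the acetoxy group of compound 2.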